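Ethyl ester step carried across two related cores

A few compounds are considered here, and "the series" means these few. Any claim that something is new, unique, unknown or untested is made for them only; others in the source may bear on it.

Three compounds measured in a functional assay on a cell-free system (Platelet, plasma, Oryctolagus cuniculus) for inhibition, with a stated time of 5 min, at 37 degrees C (a lower number here means a stronger inhibitor, a higher number a weaker inhibitor), share an ester-linked core and a 2-carboxyethenyl or 2-(ethoxycarbonyl)ethenyl arm, differing in where that arm and the methoxy group sit. Compound 1 `COc1ccc(OC(=O)c2nc(C)c(C)nc2C)c(/C=C/C(=O)O)c1` gives 49000 nM; compound 2 `COc1ccc(/C=C/C(=O)O)cc1OC(=O)c1nc(C)c(C)nc1C` gives 41800 nM. Compound 1 and compound 2 have the same atoms joined differently; the difference between the two cores is not broken down here, and their two values lie within the scatter of each other. Compound 3 `CCOC(=O)/C=C/c1ccc(OC)c(OC(=O)c2nc(C)c(C)nc2C)c1` gives 143000 nM.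

One change is seen with a measured pair: ethyl in place of hydrogen on an oxygen next to a carbonyl group, and it gave a 3.4-fold higher number from compound 2 to compound 3 (0.53 log units; beyond the scatter).

Compound 4 `CCOC(=O)/C=C/c1cc(OC)ccc1OC(=O)c1nc(C)c(C)nc1C` is not yet measured. It differs from compound 1 by ethyl in place of hydrogen on an oxygen next to a carbonyl group. The place line is the same word for word as that of the change from compound 2 to compound 3, so on this core the same change is made.

Among the compounds with values here, with only one measured instance, the expectation rests on that single step. Given that the weaker number of compound 3 follows the ethyl ester change shown by a 3.4-fold higher number from compound 2 to compound 3 (0.53 log units; beyond the scatter), the step from compound 1 to compound 4 is expected to be a 3.4-fold higher number from compound 1 to compound 4 (0.53 log units; beyond the scatter). Compound 4 is accordingly estimated at 165000 nM in this assay, with an expected range from 80000 nM to 350000 nM.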

Compound 4, half-maximal inhibitory concentration: 196000 nM
Compound 4: middle estimate off by 1.2-fold (0.07 log units), on the low side, and the stated range covers the measured number.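

In this assay, the change from 2-carboxyethenyl to 2-(ethoxycarbonyl)ethenyl gives a 4.0-fold higher number from compound 1 to compound 4 (0.60 log units; beyond the scatter), so the higher number seen on the first core recurs on the second. Within this series, the step therefore carries from one core to the other in both direction and size, and the two cores give no measurable difference in its effect: the same change on two cores in this assay, a 3.4-fold higher number (0.53 log units; beyond the scatter) from compound 2 to compound 3 and a 4.0-fold higher number (0.60 log units; beyond the scatter) from compound 1 to compound 4, 1.2-fold (0.07 log units) apart, within the scatter of two such steps

Within the data shown here, this rests on only two pairs in a single assay, with cores that differ only in where the arm and the methoxy group sit, so it does not establish a rule for other cores, and it does not explain why the ethyl ester gives the higher number.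

The compounds shown leave open whether a methyl ester, a longer chain such as butyl on the same oxygen, or an amide in place of the ester would follow the same step. Also open, as far as these compounds go, is whether the step would hold if the methoxy group were replaced by a hydroxy group or a chlorine atom, or if the ester link of the shared core were replaced by an amide.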